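Furan Regioisomer Step in Cytotoxicity

A few compounds are considered here, and "the series" means these few. Any claim that something is new, unique, unknown or untested is made for them only; others in the source may bear on it.

Compound 1 `OC[C@H]1O[C@@H](n2cc(F)c3c(-c4c[nH]cn4)ncnc32)[C@H](O)[C@@H]1O` is the phosphate-free member of the set. In an ADME assay on BJ cells (Homo sapiens) for cytotoxicity, read by MTT assay, with a stated time of 72 h (a lower number here means that less compound is tolerated, a higher number that more compound is tolerated), compound 1 gives only a limit, > 50000 nM. Compound 2 `CCCCCCCCCCCCCCCCCCOP(=O)(O)OC[C@H]1O[C@@H](n2ccc3c(-c4ccccc4)ncnc32)[C@H](O)[C@@H]1O` carries the lipid phosphate. Compound 2 also reaches only the limit, > 50000 nM. Compound 3 `CCCCCCCCCCCCCCCCCCOP(=O)(O)OC[C@H]1O[C@@H](n2ccc3c(-c4ccco4)ncnc32)[C@H](O)[C@@H]1O` carries furan-2-yl in place of phenyl on an aromatic carbon. The step that the two limits leave unreadable from compound 2 to compound 3 cannot be sized. Compound 3 likewise gives only a limit, > 50000 nM. So compound 3 stands at the limit, with no number of its own, and the limit of > 50000 nM in this assay, at which 3 of the 3 values shown sit, shows every value of the set sitting there.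

Compound 4 `CCCCCCCCCCCCCCCCCCOP(=O)(O)OC[C@H]1O[C@@H](n2ccc3c(-c4ccoc4)ncnc32)[C@H](O)[C@@H]1O` is the new member. furan-3-yl in place of furan-2-yl on an aromatic carbon Only the unreadable step from compound 2 to compound 3 bears on this change, and it gives neither size nor direction. With every measured value at the limit, no step beyond the scatter is expected, and a step that the limit leaves unreadable from compound 3 to compound 4 is the expected outcome. Compound 4 is therefore estimated at 80000 nM, within 40000 nM to 200000 nM, most likely reported again only as a limit.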

Compound 4, half-maximal cytotoxic concentration: 44200 nM
The estimate for compound 4 lay 1.8-fold (0.26 log units) above the measured number; measured number inside the range.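

In this assay, among these compounds, compound 4 gives the first number of its own, 44200 nM. A group at this aromatic carbon of the shared core can therefore give a reading rather than only a limit: the limit of > 50000 nM in this assay, at which 3 of the 4 values shown sit.

Furan-3-yl in place of furan-2-yl, the same atoms joined differently, gives an at least 1.1-fold lower number from compound 3 to compound 4 (0.05 log units; that floor lies within the scatter). Furan-3-yl in place of phenyl gives an at least 1.1-fold lower number from compound 2 to compound 4 (0.05 log units; that floor lies within the scatter).

On these data alone, both steps are floors and not sizes, so how far the attachment point of the furan matters for tolerance in BJ cells remains open. Also open, as far as these compounds go, is whether a thiophene ring, a pyridine ring or an amine at this aromatic carbon would give a number or return to the limit.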